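Trimming the amide to a hydrazide on a shared dihydroxypyrimidine core

A few compounds are considered here, and "the series" means these few. Any claim that something is new, unique, unknown or untested is made for them only; others in the source may bear on it.

Measured compounds: compound 1 `CC(C)(NC(=O)OCc1ccccc1)c1nc(O)c(O)c(C(=O)N/N=C/c2ccc(F)cc2)n1` 378000 nM; compound 2 `COc1ccc(CNC(=O)c2nc(C(C)(C)NC(=O)OCc3ccccc3)nc(O)c2O)cc1` 164000 nM; compound 3 `CC(C)(NC(=O)OCc1ccccc1)c1nc(O)c(O)c(NC(=O)NCc2ccc(F)cc2)n1` 81100 nM.

In an ADME assay on C8166 cells (Homo sapiens) for cytotoxicity, read by MTT assay, with a stated time of 3 days (on this read-out higher numbers stand for lower toxicity in this test and lower numbers for higher toxicity in this test), compound 2 gives 164000 nM, the second highest of the three numbers, with compound 3 below and compound 1 above it. Compound 4 `CC(C)(NC(=O)OCc1ccccc1)c1nc(O)c(O)c(C(=O)NN)n1` differs from compound 2 by amino in place of 4-methoxybenzyl on an amide-type nitrogen. Among the compounds with values here, the only measured step on this amide-type nitrogen is a 2.3-fold lower number from compound 1 to compound 2 (0.36 log units; beyond the scatter), which swapped one ring-bearing group for another; none removes the whole group. The three numbers span a narrow range, so a modest step is expected at most. Compound 4 is estimated at 300000 nM (range 100000 nM to 900000 nM), a step of a 1.8-fold higher number from compound 2 to compound 4 (0.26 log units; within the scatter) expected toward a higher number.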

Compound 4, half-maximal cytotoxic concentration: > 500000 nM
Compound 4: only a limit was reported; the forecaster's own chance of this, stated with the estimate: 30%; middle value at least 1.6-fold (0.22 log units) away from the limit.
By their numbers in this assay, from the lowest: compound 3; then compound 2; then compound 1. At a limit, above all of these: compound 4.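

Putting amino in place of 4-methoxybenzyl on this amide-type nitrogen removes the ring altogether, which the earlier swap of one ring-bearing group for another did not do, and in this assay this gives an at least 3.0-fold higher number from compound 2 to compound 4 (0.48 log units; beyond the scatter). The second step, an at least 1.3-fold higher number from compound 1 to compound 4 (0.12 log units; that floor lies within the scatter), has a floor that lies within the scatter, so it shows no clear separation. The reading for compound 4 is a limit of the assay, not a number: the limit of > 500000 nM in this assay, at which 1 of the 4 values shown sits.

The compounds shown leave open how far the number for compound 4 extends past that limit. They also leave open whether a methyl group or a hydroxyl group on this nitrogen would read like amino, which would separate losing the ring from adding amino.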